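The compounds below may be only part of what the source reports. "The series", "measured", "known", "first", "only" and "open" are said of these compounds alone.

Compound 1 `O=C(O)CCc1cc(Cc2cccnc2)cc2c1CCC(NS(=O)(=O)c1ccc(Cl)cc1)C2` holds the lower of the two numbers in a functional assay (Saphenous vein) for inhibition, with Oryctolagus cuniculus as the target (a higher number here means weaker binding, a lower number tighter binding), where compound 1 gives 0.2 nM. Going by the values given here, compound 2 `O=C(O)CCc1c2c(cc(Cc3cccnc3)c1-c1ccccc1)CC(NS(=O)(=O)c1ccc(Cl)cc1)CC2` gives 0.794 nM; the only measured step, a 4.0-fold higher number from compound 1 to compound 2 (0.60 log units; beyond the scatter), concerns phenyl in place of hydrogen on an aromatic carbon and leaves the 2-carboxyethyl group untouched. Compound 3 `O=C(O)CCC/C=C\c1cc(Cc2cccnc2)cc2c1CCC(NS(=O)(=O)c1ccc(Cl)cc1)C2` carries 5-carboxypent-1-en-1-yl in place of 2-carboxyethyl on an aromatic carbon. Among the compounds with values here, no measured step bears on this change, so the expectation rests on compound 1 alone and allows only a modest shift in this assay in either direction. Compound 3 is estimated at 0.4 nM, range 0.1 nM to 1.6 nM, an expected step of a 2.0-fold higher number from compound 1 to compound 3 (0.30 log units; within the scatter).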

Compound 3, dissociation constant: 2.51 nM
Beside the measured number, compound 3's estimate is 6.3-fold (0.80 log units) below it, outside the stated range (above it).
By their numbers in this assay, from the lowest: compound 1; then compound 2; then compound 3.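

Exchanging 2-carboxyethyl for 5-carboxypent-1-en-1-yl on the core of compound 1 gives, in this assay, a 13-fold higher number from compound 1 to compound 3 (1.10 log units; beyond the scatter). This position therefore responds to a change in the chain carrying the carboxylic acid, although the counts of hydrogen-bond donors and acceptors stay the same. No supporting data bear on the origin of this step.

The compounds shown leave open whether the added chain length or the new double bond accounts for the step. A saturated 5-carboxypentyl chain at this position would separate the two.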